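The source may report more compounds than this note shows. Statements on the series, on what has been measured and on what is new or still open speak of the compounds shown alone.

Compound 1, `Cc1cc(C)cc(SCc2ccc(/C=C/C(=O)Nc3ccccc3N)cc2)c1`, stands highest of the two compounds measured in a functional assay on A549 cells (Homo sapiens) for inhibition, read by CCK-8 assay, with a stated time of 72 h, tested at 2 uM (on this read-out lower numbers stand for less inhibition of growth and higher numbers for more inhibition of growth at the one concentration tested), where compound 1 gives 46.1%. Compound 2, `COc1ccc(SCc2ccc(C(=O)Nc3ccccc3N)cc2)cc1OC`, gives 19.9% in this assay, a gap beyond the usual scatter. Compound 3, `CC(C)(C)c1ccc(SCc2ccc(/C=C/C(=O)Nc3ccccc3N)cc2)cc1`, differs from compound 1 in one place: 4-(tert-butyl)phenyl in place of 3,5-dimethylphenyl on a sulfur. Within the data shown here, no measured pair shows what this change does on its own. In this assay only a small step is expected, a number 1.9 percentage points higher from compound 1 to compound 3 (within the scatter), not clearly beyond the scatter in either direction. Compound 3 is therefore estimated at 48%, with a likely range from 30% to 65%.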

Compound 3, percent growth inhibition at one concentration: 71.5%
Estimate against measurement, compound 3: 23.5 percentage points below; measured number above the stated range.
By their numbers in this assay, from the lowest: compound 2; then compound 1; then compound 3.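

The group on the sulfur clearly matters: in this assay, 4-(tert-butyl)phenyl in place of 3,5-dimethylphenyl gives a number 25.4 percentage points higher from compound 1 to compound 3 (beyond the scatter). Both groups are carbon-only aromatic groups with no hydrogen-bond donors or acceptors, yet the change in growth inhibition is clear. No measurement shown here accounts for the size of this step. On these data alone, it remains open whether 4-methylphenyl, or a phenyl group carrying an amine or a carboxylic acid, would keep this gain on the same sulfur.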